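Amino for nitro on the phenyl of compound 1

A few compounds are considered here, and "the series" means these few. Any claim that something is new, unique, unknown or untested is made for them only; others in the source may bear on it.

Compound 1 `O=C(CCN1CCN(c2ccc([N+](=O)[O-])cc2)CC1)c1csc2ccccc12` is run in an assay on HEK293 cells for displacement of a labelled ligand from 5-hydroxytryptamine receptor 7 (Homo sapiens), read by scintillation counting, with a stated time of 1 h; on this read-out higher numbers stand for weaker inhibition and lower numbers for stronger inhibition. In this assay compound 1 gives only a limit of the assay, > 100000 nM. Compound 3 `O=[N+]([O-])c1ccc(N2CC[C@@H](NCCC(O)c3csc4ccccc34)C2)cc1` also reaches only a limit in this assay, > 100000 nM; these two limits are the limit of > 100000 nM in this assay, at which 2 of the 3 values shown sit. Among the compounds with values here, compound 2 `O=[N+]([O-])c1ccc(N2CCCN(CCC(O)c3csc4ccccc34)CC2)c(C(F)(F)F)c1` is the one compound with a number in this assay, giving 8710 nM. Compound 4 `Nc1ccc(N2CCN(CCC(=O)c3csc4ccccc34)CC2)cc1` differs from compound 1 by amino in place of nitro on an aromatic carbon. Within the data shown here, no measured pair shows this change, so no size or direction can be read for it, and compound 1 offers only a limit as anchor. In this assay compound 4 is expected near 60000 nM, with a range from 8000 nM to 300000 nM. The step expected from compound 1 to compound 4 is an at least 1.6-fold lower number from compound 1 to compound 4 (0.22 log units; that floor lies within the scatter), of uncertain direction and plausibly within the scatter.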

Compound 4, inhibition constant: 14100 nM
Beside the measured number, compound 4's estimate is 4.3-fold (0.63 log units) above it; the measured number falls inside the stated range.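

In this assay, within the data shown here, the change from 4-nitrophenyl to 4-aminophenyl gives an at least 7.0-fold lower number from compound 1 to compound 4 (0.85 log units; beyond the scatter), the first reading of a change at this position. The position therefore responds to the group it carries, and amino brings the core of compound 1 off the limit to a measured number. Compound 1 stands at a limit, so the step is only a floor, and that limit recurs in the series: the limit of > 100000 nM in this assay, at which 2 of the 4 values shown sit.

As far as these compounds go, whether a hydroxyl, a methoxy group or an acetamide at this place would move the number further stays open. So does whether amino in place of nitro gives a similar step on compound 2 or compound 3.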